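Series notes: methoxy in place of methyl, compound 3

A few compounds are considered here, and "the series" means these few. Any claim that something is new, unique, unknown or untested is made for them only; others in the source may bear on it.

Measured in a functional assay on PC-3 cells (Homo sapiens) for cytotoxicity, read by MTT assay, with a stated time of 72 h; a lower number here means a stronger inhibitor, a higher number a weaker inhibitor:
compound 1, `Cc1ccc(S(=O)(=O)c2nc3ccccc3nc2Nc2ccc(F)cc2)cc1`: 13100 nM
compound 2, `Cc1ccc(S(=O)(=O)c2nc3ccccc3nc2Nc2ccc(Cl)cc2)cc1`: 9660 nM

Going by the values given here, compound 2 and compound 1 lie within the scatter of each other in this assay; the one measured step is a 1.4-fold lower number from compound 1 to compound 2 (0.13 log units; within the scatter), a halogen swap on the aniline-side ring, and it separates nothing.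

Compound 3, `COc1ccc(S(=O)(=O)c2nc3ccccc3nc2Nc2ccc(Cl)cc2)cc1`, differs from compound 2 by methoxy in place of methyl on an aromatic carbon. Among the compounds with values here, no measured pair in this set compares methyl with methoxy at that place, and the single step on record, a 1.4-fold lower number from compound 1 to compound 2 (0.13 log units; within the scatter), concerns a different ring and a different kind of group, so it carries little over to this change. With a small exchange at a remote site and no evidence of sensitivity there, the expected step is a 1.0-fold lower number from compound 2 to compound 3 (0.01 log units; within the scatter), nothing beyond the scatter in either direction. Compound 3 is therefore estimated at 9500 nM in this assay, with a range from 4000 nM to 22000 nM.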

Compound 3, half-maximal inhibitory concentration: 31800 nM
Beside the measured number, compound 3's estimate is 3.3-fold (0.52 log units) below it; measured number above the stated range.
By their numbers in this assay, from the lowest: compounds 2 and 1 (each within the scatter of the next); then compound 3.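

In this assay, going by these compounds alone, the change from 4-methylphenyl to 4-methoxyphenyl gives a 3.3-fold higher number from compound 2 to compound 3 (0.52 log units; beyond the scatter) and is the first step beyond the scatter. The earlier compounds shown here varied only the halogen and separated nothing, whereas this result shows that the position para to a large group on the other aromatic ring is not indifferent to the group it carries, at least for this single pair. Nothing available bears on the reason for this step.

As far as these compounds go, it remains open whether a hydroxyl, an amine or a longer chain at this position would raise the number further or bring it below that of compound 2. From the compounds shown here alone, the step also rests on a single chloro pair, so its size with fluoro in place of chloro remains open.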